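The source may hold more compounds than are shown below. What is called first, only, known or untested is meant among the compounds shown, and "the series" means these compounds.

In a functional assay on A549 cells (Homo sapiens) for inhibition, read by sulforhodamine B assay, with a stated time of 48 h (on this read-out higher numbers stand for weaker inhibition and lower numbers for stronger inhibition), two compounds sharing one core have been measured so far. Compound 1 `CCO[C@H]1C[C@@H](c2coc3ccccc3c2=O)N(c2ccccc2)O1` gives > 60000 nM, which is a limit of the assay and not a number. Compound 2 `O=c1c([C@@H]2C[C@H](c3ccccc3)ON2c2ccccc2)coc2ccccc12` gives > 60000 nM, which is also only a limit. The whole record so far is therefore (the limit of > 60000 nM in this assay, at which 2 of the 2 values shown sit), and compound 2 has no exact value to start from. For the measured compounds named here, the one measured change, phenyl in place of ethoxy on a saturated ring carbon, is a step that the two limits leave unreadable from compound 1 to compound 2.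

Compound 3 `O=c1c([C@@H]2C[C@H](c3ccncc3)ON2c2ccccc2)coc2ccccc12` keeps the core of compound 2 and changes that same ring carbon once more: pyridin-4-yl in place of phenyl on a saturated ring carbon. In words, pyridin-4-yl takes the place of phenyl. The earlier step, a step that the two limits leave unreadable from compound 1 to compound 2, offers no size to carry over, so no change beyond the scatter is expected in this assay. The estimated change is a number no higher from compound 2 to compound 3 (the limit leaves the size open). For compound 3 the estimated value is 60000 nM, with an expected range from 20000 nM to 120000 nM, and the assay may well report only a limit again.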

Compound 3, half-maximal inhibitory concentration: 19300 nM
Beside the measured number, compound 3's estimate is 3.1-fold (0.49 log units) above it, and the stated range ends above it.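

In this assay, the saturated ring carbon next to the ring oxygen turns out to be a place where a change can move the read-out: putting a nitrogen into the aromatic ring, as pyridin-4-yl in place of phenyl, gives an at least 3.1-fold lower number from compound 2 to compound 3 (0.49 log units; beyond the scatter). Set against ethoxy on the same carbon, pyridin-4-yl gives an at least 3.1-fold lower number from compound 1 to compound 3 (0.49 log units; beyond the scatter), so among the three groups shown it is the only one that yields a number and not a limit. Compound 3 therefore provides the first exact value in this small series, while the rest of the record stays at the edge of what the assay can report: the limit of > 60000 nM in this assay, at which 2 of the 3 values shown sit.

As far as these compounds go, the full size of both steps remains open, and the step between the other two compounds cannot be read at all, so nothing yet ranks phenyl against ethoxy. The compounds shown also leave open whether the nitrogen must sit where it does in pyridin-4-yl, as a comparison with pyridin-3-yl could show, and whether an amine or a carboxylic acid on this carbon would lower the number further.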